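A second methoxy on the aryl of compound 2

The compounds below may be only part of what the source reports. "The series", "measured", "known", "first", "only" and "open" are said of these compounds alone.

Compound 2 `COc1ccc(-c2nc(SCC(=O)c3sc(-c4ccc(Cl)cc4)nc3C)[nH]c(=O)c2C#N)cc1` gives 88.3% in a functional assay on U-87MG ATCC cells for antiproliferative activity against U-87 MG (Homo sapiens), read by MTT assay, with a stated time of 48 h, tested at 10 uM (a lower number here means a stronger effect, a higher number a weaker effect of the compound at the concentration tested), the highest of the two numbers recorded. Compound 1 `COc1ccc(-c2nc(C)c(C(=O)CSc3nc(-c4ccc(OC)c(OC)c4)c(C#N)c(=O)[nH]3)s2)cc1` gives 57.6% in this assay, and the gap between the two values lies beyond the usual scatter. Compound 3 `COc1ccc(-c2nc(SCC(=O)c3sc(-c4ccc(Cl)cc4)nc3C)[nH]c(=O)c2C#N)cc1OC` differs from compound 2 by one change, (methoxy in place of hydrogen on an aromatic carbon), taking the 4-methoxyphenyl to 3,4-dimethoxyphenyl. For the measured compounds named here, no measured pair shows this change alone, so the step from compound 2 to compound 3 in this assay is expected to be small and toward a lower number, a number 10.3 percentage points lower from compound 2 to compound 3 (beyond the scatter). Compound 3 is therefore estimated at 78%, within 60% to 95%.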

Compound 3, a percentage reported as activity, at one concentration (the size of the read-out at that concentration, not a potency): 83.3%
Compound 3: the middle estimate sits 5.3 percentage points below what was measured, within the range that was stated.
By their numbers in this assay, from the lowest: compound 1; then compounds 3 and 2 (each within the scatter of the next).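

In this assay the second methoxy gives no separation, with a number 5 percentage points lower from compound 2 to compound 3 (within the scatter), so the 4-methoxyphenyl and the 3,4-dimethoxyphenyl cannot be told apart at this position while the chloro stays in place. With the 3,4-dimethoxyphenyl held fixed, the chloro in place of methoxy at the other aromatic end gives the larger step, a number 25.7 percentage points higher from compound 1 to compound 3 (beyond the scatter). Nothing measured here offers a reason for either step. Going by these compounds, it remains open whether an amine or an ethoxy group on this same ring carbon would separate from hydrogen and methoxy. On these data alone, it is also open whether fluoro in place of the chloro would read closer to compound 1 or to compound 3.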